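Adding a Bromo Group to Compound 2

A few compounds are considered here, and "the series" means these few. Any claim that something is new, unique, unknown or untested is made for them only; others in the source may bear on it.

Among the compounds with values here, only two compounds have so far been tested in a functional assay on KB cells (Homo sapiens) for antiproliferative activity, read by sulforhodamine B assay, with a stated time of 72 h; a lower number here means a stronger inhibitor, a higher number a weaker inhibitor. Compound 1 `COc1c(OC(C)C)cc2ccc(-c3cc(=O)c4ccccc4o3)cc2c1OC(C)C` gives > 10000 nM, which is a limit of the assay and not a number. In this assay, within the data shown here, compound 2 `O=C(/C=C/c1csc2ccccc12)c1ccccc1O` gives 6200 nM, the only true number available, so it cannot yet be ranked against a second measured value.

Compound 3 `O=C(/C=C/c1csc2ccccc12)c1cc(Br)ccc1O` differs from compound 2 in one place, with bromo in place of hydrogen on an aromatic carbon. The new bromo group lies para to a hydroxy group, and the rest of the structure is unchanged.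

Among the measured compounds shown here, no measured pair shows what this replacement does in this assay, so the expectation is anchored on compound 2 at 6200 nM and remains tentative. A small shift toward stronger inhibition is expected, possibly none beyond the scatter. The estimated change is a 1.6-fold lower number from compound 2 to compound 3 (0.19 log units; within the scatter). For compound 3 the expected value is 4000 nM, with an estimated range of 1300 nM to 10000 nM.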

Compound 3, half-maximal inhibitory concentration: 760 nM
For compound 3 the middle estimate is 5.3-fold (0.72 log units) above the measured one; the measured number lies below the stated range.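

Bromo in place of hydrogen on an aromatic carbon, para to a hydroxy group and meta to a large group, gives an 8.2-fold lower number from compound 2 to compound 3 (0.91 log units; beyond the scatter) in this assay. Within the data shown here, this is the first step that can be read, and it shows that this position of the six-membered aromatic ring of carbon only responds to a single heavy atom entering there, something that compound 2 on its own, as one number with nothing to set it against, could not show. No information given here bears on why the step has this size.

Still open, as far as these compounds go, is whether the gain belongs to bromo in particular or would also appear with another group on the same aromatic carbon, such as chloro, methoxy, an amine or a carboxylic acid. Also open, from the compounds shown here alone, is whether the hydroxy group and the large group named in the place of this change matter to the step, and whether bromo would give a similar shift at another carbon of the same ring, since this single pair speaks for one position and one replacement only.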